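Swapping the larger group of compound 2 for azetidin-1-yl

The source may hold more compounds than are shown below. What is called first, only, known or untested is meant among the compounds shown, and "the series" means these compounds.

In a functional assay on MDA-MB-231 cells (Homo sapiens) for inhibition, read by MTT assay, with a stated time of 72 h (a higher number here means a weaker inhibitor, a lower number a stronger inhibitor), compound 1 `c1ccc(-c2nc(CNc3nccc(NC4CC4)n3)cs2)cc1` gives > 100000 nM, which is a limit and not a number. For the measured compounds named here, compound 2 `OC1CC2CC1CN2c1ccnc(NCc2csc(-c3ccccc3)n2)n1` gives 6460 nM, the only true number so far. Compound 3 `c1ccc(-c2nc(CNc3nccc(N4CCC4)n3)cs2)cc1` differs from it by a group of 4 heavy atoms (3 carbon, 1 nitrogen; one four-membered non-aromatic ring with 1 hetero atom) in place of a group of 8 heavy atoms (6 carbon, 1 nitrogen, 1 oxygen; one five-membered non-aromatic ring of carbon only, one five-membered non-aromatic ring with 1 hetero atom), on an aromatic carbon. Going by the values given here, the one measured step bearing on this is an at least 15-fold lower number from compound 1 to compound 2 (1.18 log units; beyond the scatter), large and beyond the scatter, and the new change runs the opposite way, towards a smaller group. That step rests on (the limit of > 100000 nM in this assay, at which 1 of the 2 values shown sits). A large move towards weaker inhibition is therefore expected, as a 4.6-fold higher number from compound 2 to compound 3 (0.67 log units; beyond the scatter). For compound 3 the estimate is 30000 nM, with an expected range of 8000 nM to 100000 nM.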

Compound 3, half-maximal inhibitory concentration: 27700 nM
Beside the measured number, compound 3's estimate is 1.1-fold (0.03 log units) above it; the measured number falls inside the stated range.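

In this assay, azetidin-1-yl on this aromatic carbon gives a true number where cyclopropylamino gave none, with an at least 3.6-fold lower number from compound 1 to compound 3 (0.55 log units; beyond the scatter). For the compounds shown here, compound 1 gives > 100000 nM, which is a limit, so that step has no exact size: the limit of > 100000 nM in this assay, at which 1 of the 3 values shown sits. The larger group of compound 2 still outdoes azetidin-1-yl, with a 4.3-fold higher number from compound 2 to compound 3 (0.63 log units; beyond the scatter), the first step here with a true number at both ends. Open, from the compounds shown here alone, is whether the oxygen or the size of that larger group carries this difference, and how a piperidine or a morpholine would read at this place.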